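Trifluoromethyl Added to a Chlorobenzyl Thioether

A few compounds are considered here, and "the series" means these few. Any claim that something is new, unique, unknown or untested is made for them only; others in the source may bear on it.

The series shares one core. Compound 1 `Cn1cc(SCc2nnc(S)n2-c2c(Cl)cccc2Cl)c2ccccc21` carries a free thiol on that core. In a toxicity assay on HEK-293T cells (Homo sapiens) for cytotoxicity, read by CCK-8 assay, with a stated time of 48 h (a higher number here means that more compound is tolerated, a lower number that less compound is tolerated), compound 1 gives only a limit of > 100000 nM (the limit of > 100000 nM in this assay, at which 1 of the 3 values shown sits). Compound 2 `Cn1cc(SCc2nnc(SCc3ccccc3C#N)n2-c2c(Cl)cccc2Cl)c2ccccc21` bears a 2-cyanobenzyl on that sulfur, and in this assay compound 2 gives 78600 nM. Compound 3 `Cn1cc(SCc2nnc(SCc3ccccc3Cl)n2-c2c(Cl)cccc2Cl)c2ccccc21` bears a 2-chlorobenzyl instead, and in this assay compound 3 gives 49600 nM. The step of an at least 1.2-fold lower number from compound 1 to compound 2 (0.10 log units; that floor lies within the scatter) and the step of an at least 2.0-fold lower number from compound 1 to compound 3 (0.30 log units; that floor lies within the scatter) both start from a limit. Between the two numbers, a 1.6-fold lower number from compound 2 to compound 3 (0.20 log units; within the scatter), so compound 3 stands at the low end of the two measured values, with compound 2 alongside it within the scatter.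

Compound 4 `Cn1cc(SCc2nnc(SCc3cc(C(F)(F)F)ccc3Cl)n2-c2c(Cl)cccc2Cl)c2ccccc21` differs from compound 3 by trifluoromethyl in place of hydrogen on an aromatic carbon. Going by the values given here, the only measured step on that ring, a 1.6-fold lower number from compound 2 to compound 3 (0.20 log units; within the scatter), stayed within the scatter, and no measured step adds a group to that ring. No step beyond the scatter is therefore expected in this assay from compound 3 to compound 4; the expected change is a 1.2-fold lower number from compound 3 to compound 4 (0.09 log units; within the scatter). Compound 4 is estimated at 40000 nM, between 15000 nM and 100000 nM.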

Compound 4, half-maximal cytotoxic concentration: 53800 nM
Beside the measured number, compound 4's estimate is 1.3-fold (0.13 log units) below it; low and high end bracket the measured number.
By their numbers in this assay, from the lowest: compounds 3, 4 and 2 (each within the scatter of the next). At a limit, above all of these: compound 1.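

Here a measured step adds a group to that ring for the first time, and at this position, para to a chloro group, trifluoromethyl leaves the number in this assay within the scatter: a 1.1-fold higher number from compound 3 to compound 4 (0.04 log units; within the scatter). Exchanging the whole aryl group gives the same picture, a 1.5-fold lower number from compound 2 to compound 4 (0.16 log units; within the scatter), so the 2-cyanobenzyl, 2-chlorobenzyl and 2-chloro-5-(trifluoromethyl)benzyl thioethers all lie within the scatter of one another. The step of an at least 1.8-fold lower number from compound 1 to compound 4 (0.26 log units; that floor lies within the scatter) gives only a floor, which rests on a limit and not on a number: the limit of > 100000 nM in this assay, at which 1 of the 4 values shown sits.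

The compounds shown leave open whether an amine or a carboxylic acid at this position would move the number beyond the scatter. They also leave open what a longer chain in place of the benzyl group on the sulfur would do.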